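Aryl exchange from compound 3 to compound 4

The source may hold more compounds than are shown below. What is called first, only, known or untested is meant among the compounds shown, and "the series" means these compounds.

Among the compounds with values here, in a functional assay on KB cells (Homo sapiens) for antiproliferative activity, read by sulforhodamine B assay, with a stated time of 3 days (on this read-out lower numbers stand for an effect already at smaller amounts and higher numbers for an effect only at larger amounts of compound), compound 3 `CCC1=C(O)c2c(oc(-c3cc(C)ccc3C)cc2=O)C(CC)(CC)C1=O` gives 14.5 uM, the only number so far. Compound 1 `CCC1=C(O)c2c(oc(-c3ccc(Br)cc3)cc2=O)C(CC)(CC)C1=O` reads > 48.1 uM, which is a limit. Compound 2 `CCC1=C(O)c2c(oc(-c3ccc(COC)cc3)cc2=O)C(CC)(CC)C1=O` reads > 52.4 uM, which is also a limit.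

Compound 4 `CCC1=C(O)c2c(oc(-c3ccc(F)c(C)c3)cc2=O)C(CC)(CC)C1=O` has 4-fluoro-3-methylphenyl in place of 2,5-dimethylphenyl on an aromatic carbon, next to the ring oxygen of the shared core (4-fluoro-3-methylphenyl in place of 2,5-dimethylphenyl on an aromatic carbon).

Within the data shown here, two measured steps bear on this change, an at least 3.3-fold lower number from compound 1 to compound 3 (0.52 log units; beyond the scatter) and an at least 3.6-fold lower number from compound 2 to compound 3 (0.55 log units; beyond the scatter). Both are at least modest, beyond the scatter, and end at 2,5-dimethylphenyl. The entering group, like the groups left behind in those two steps, is substituted at its 4 position, so a modest move to a higher number is expected. This expectation rests on very few compounds, and neither of those steps involves fluoro or a retained methyl group. The estimated step is a 1.9-fold higher number from compound 3 to compound 4 (0.29 log units; within the scatter). The estimate for compound 4 is 28 uM, with an expected range of 11 uM to 70 uM.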

Compound 4, concentration for half-maximal effect: 40.5 uM
For compound 4 the middle estimate is 1.4-fold (0.16 log units) below the measured one; measured number inside the range.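

In this assay the exchange gives a 2.8-fold higher number from compound 3 to compound 4 (0.45 log units; beyond the scatter), so this place responds to the aryl pattern even between two groups that each hold one six-membered aromatic ring of carbon only, with no hydrogen-bond donors or acceptors. Against the other two aryl groups there are only floors, an at least 1.2-fold lower number from compound 2 to compound 4 (0.11 log units; that floor lies within the scatter) and an at least 1.1-fold lower number from compound 1 to compound 4 (0.07 log units; that floor lies within the scatter); both rest on limits rather than numbers, so compound 4 cannot be separated from compound 1 or compound 2. Compound 3 keeps the lowest number of the four, with its steps to all three others beyond the scatter.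

Fluoro and methyl change together here, so a 4-fluorophenyl or 3-methylphenyl group would be needed to show which of them carries the step. As far as these compounds go, how an aminomethyl group or a carboxylic acid on the aryl ring would read remains open.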